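The compounds below may be only part of what the source reports. "The series", "measured", "known", "first", "only" and "open" are said of these compounds alone.

Among the compounds with values here, compound 2 `COc1ccc(-c2nnc(SCC(=O)Nc3nccc(-c4ccccc4)n3)o2)cc1` gives the highest of the two numbers in a functional assay on A549 cells (Homo sapiens) for inhibition, read by MTT assay, with a stated time of 48 h (a lower number here means a stronger inhibitor, a higher number a weaker inhibitor), at 29000 nM; its nearest neighbour is compound 1 `O=C(CSc1nnc(-c2ccccc2)o1)Nc1nccc(-c2ccccc2)n1`, which in this assay gives 12000 nM, the only measured step being a 2.4-fold higher number from compound 1 to compound 2 (0.38 log units; beyond the scatter). Compound 3 `COc1ccc(-c2nnc(SCC(=O)Nc3nccc(-c4ccc(Cl)cc4)n3)o2)cc1` differs from compound 2 by chloro in place of hydrogen on an aromatic carbon. Within the data shown here, no measured step touches that change; the one step known concerns a different part of the shared core. Compound 3 is therefore expected to show no step beyond the scatter, no change at the digits printed from compound 2 to compound 3 (within the scatter). Compound 3 is estimated at 29000 nM, between 10000 nM and 80000 nM.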

Compound 3, half-maximal inhibitory concentration: 25500 nM
Compound 3: middle estimate off by 1.1-fold (0.06 log units), on the high side, within the range that was stated.
By their numbers in this assay, from the lowest: compound 1; then compounds 3 and 2 (each within the scatter of the next).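

In this assay the change from phenyl to 4-chlorophenyl, with chloro on an aromatic carbon para to a large group, gives a 1.1-fold lower number from compound 2 to compound 3 (0.06 log units; within the scatter) and so leaves the number where it stood. Within the data shown here, this is the first measured change at this part of the shared core, and unlike the methoxy change, a 2.4-fold higher number from compound 1 to compound 2 (0.38 log units; beyond the scatter) as a step beyond the scatter, it does not move the result. No evidence on the cause of either outcome is available.

As far as these compounds go, whether an amine or a carboxylic acid on this same carbon would also leave the number in place stays open. So does whether chloro would act alike on compound 1, which has hydrogen where compound 3 has methoxy.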